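Series notes: compound 3 to compound 4

The source may hold more compounds than are shown below. What is called first, only, known or untested is meant among the compounds shown, and "the series" means these compounds.

Of the compounds shown here, three of the shared core have been measured in an assay on membranes from HeLa cells for displacement of a labelled ligand from adenosine receptor A3 (Homo sapiens), read by scintillation counting, with a stated time of 180 min, tested at 1 uM; on this read-out higher numbers stand for more inhibition at the one concentration tested (going by the name of the read-out) and lower numbers for less inhibition. Compound 1 `CCCOC(=O)C1=C(C)NC(=O)NC1c1ccsc1` gives 6%, compound 2 `CC1=C(C(=O)NC(C)C)C(c2ccsc2)NC(=O)N1` gives 1% and compound 3 `CC1=C(C(=O)OC2CCC2)C(c2ccoc2)NC(=O)N1` gives 1%. Compound 3 stands level with compound 2 at the digits shown and within the scatter of compound 1, so all three numbers sit together at the low end of the read-out.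

Compound 4 `CC1=C(C(=O)OC2CCC2)C(c2ccsc2)NC(=O)N1` differs from compound 3 in one place: thiophen-3-yl in place of furan-3-yl on a saturated ring carbon. Among the measured compounds shown here, the one measured step, a number 5 percentage points lower from compound 1 to compound 2 (within the scatter), changes the group on the carbonyl carbon and leaves the five-membered ring alone, so it does not bear on this change; it only shows that the read-out stayed flat under a change elsewhere. Compounds 1 and 2 both carry thiophen-3-yl and give low numbers, as does compound 3 with furan-3-yl. No step beyond the scatter is therefore expected in this assay; the estimated step is a number 2 percentage points higher from compound 3 to compound 4 (within the scatter).

For compound 4 the expected value is 3%, with a range from -7% to 13%.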

Compound 4, a percentage reported as inhibition, at one concentration (the size of the read-out at that concentration, not a potency): 3%
Beside the measured number, compound 4's estimate shows no gap at the digits printed, within the range that was stated.
By their numbers in this assay, from the lowest: compounds 2, 3, 4 and 1 (each within the scatter of the next).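

In this assay, among the compounds shown here, thiophen-3-yl in place of furan-3-yl on a saturated ring carbon gives a number 2 percentage points higher from compound 3 to compound 4 (within the scatter) as the first direct reading of this exchange, and the two rings cannot be told apart on this read-out. With thiophen-3-yl held, the group on the carbonyl carbon also leaves the read-out flat: cyclobutyloxy in place of isopropylamino gives a number 2 percentage points higher from compound 2 to compound 4 (within the scatter) and cyclobutyl in place of propyl on the oxygen gives a number 3 percentage points lower from compound 1 to compound 4 (within the scatter) as well. Nothing at hand offers an explanation for these readings.

As far as these compounds go, all four numbers sit together at the low end of the read-out, so it stays open whether any group on this ring carbon moves it. A phenyl or pyridin-3-yl ring there, or a carboxylic acid on the carbonyl carbon, would be a further test.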